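A few compounds are considered here, and "the series" means these few. Any claim that something is new, unique, unknown or untested is made for them only; others in the source may bear on it.

Measured compounds:
- compound 1 `OCc1cccc(C2=NCCCC2)c1`: 35000 nM
- compound 2 `OCc1cc(F)cc(C2=NCCCC2)c1`: 744 nM
- compound 3 `Oc1cccc(C2=NCCCC2)c1`: 32000 nM

All three share one core and were tested in an assay on cell membranes for displacement of a labelled ligand from Neuronal acetylcholine receptor; alpha4/beta2 (Rattus norvegicus), read by radioligand binding, with a stated time of 30 min; on this read-out higher numbers stand for weaker inhibition and lower numbers for stronger inhibition. Among them compound 1 gives 35000 nM, the highest of the three numbers. Compound 3 stands nearest to it with 32000 nM; the step from compound 1 to compound 3 is a 1.1-fold lower number from compound 1 to compound 3 (0.04 log units; within the scatter), so the two cannot be told apart on this read-out. Compound 2, with 744 nM, stands furthest away, and the step from compound 1 to compound 2 is a 47-fold lower number from compound 1 to compound 2 (1.67 log units; beyond the scatter).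

Compound 4 `c1ccc(C2=NCCCC2)cc1` has not yet been measured. It differs from compound 1 in a single place: hydrogen in place of hydroxymethyl on an aromatic carbon. Going by the values given here, of the two measured steps, the one from compound 1 to compound 3 is the closer relative, as it too takes the hydroxymethyl away, though it puts hydroxy in its place, and that step stayed within the scatter. The step from compound 1 to compound 2 adds fluoro elsewhere and offers no direct guide. The expected step in this assay is therefore small, estimated as a 1.2-fold lower number from compound 1 to compound 4 (0.07 log units; within the scatter), with nothing beyond the scatter foreseen. For compound 4 the estimated value is 30000 nM, expected to fall between 8000 nM and 100000 nM.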

Compound 4, inhibition constant: 2080 nM
Compound 4: middle estimate off by 14-fold (1.16 log units), on the high side; the whole stated range lies above it.
By their numbers in this assay, from the lowest: compound 2; then compound 4; then compounds 3 and 1 (each within the scatter of the next).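

In this assay, the hydroxymethyl-to-hydroxy swap had suggested that this aromatic carbon was insensitive to change, but that swap only compared two groups that behave alike on this read-out. Replacing the hydroxymethyl with plain hydrogen gives a 17-fold lower number from compound 1 to compound 4 (1.23 log units; beyond the scatter) and replacing the hydroxy with hydrogen gives a 15-fold lower number from compound 3 to compound 4 (1.19 log units; beyond the scatter), so this position does matter, and here both oxygen-bearing groups go with much weaker inhibition than hydrogen does. No measurement shown here explains this difference.

The compounds leave open whether the weaker inhibition follows from having any group on this carbon or is specific to these two, and a methyl, a methoxy, an amine or a carboxylic acid in the same place would help to separate those possibilities, as would a longer chain. Going by these compounds, it also remains open whether the fluoro that made such a large difference in compound 2 would lower the number to a similar extent on compound 4, which carries only hydrogen in place of the hydroxymethyl.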